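From Methyl to Phenyl on the Amine Nitrogen

A few compounds are considered here, and "the series" means these few. Any claim that something is new, unique, unknown or untested is made for them only; others in the source may bear on it.

Measured compounds:
compound 1 `CC(C)NNc1nnc(-c2ccccc2Cl)s1` gives 50 mg/kg
compound 2 `CNN(C)c1nnc(-c2ccccc2C)s1` gives 10 mg/kg
compound 3 `CNN(C)c1nnc(-c2ccccc2Cl)s1` gives 43 mg/kg

All three were tested in a functional assay on the whole organism with Mus musculus as the target, in the maximal electroshock model, with a stated time of 1 h; on this read-out higher numbers stand for an effect only at larger amounts of compound and lower numbers for an effect already at smaller amounts. Compound 3, at 43 mg/kg, holds the second highest of the three numbers. The nearest neighbour is seen in a 1.2-fold lower number from compound 1 to compound 3 (0.07 log units; within the scatter), a difference within the scatter; the furthest is seen in a 4.3-fold higher number from compound 2 to compound 3 (0.63 log units; beyond the scatter), a modest step beyond the scatter.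

Compound 4 `CN(Nc1ccccc1)c1nnc(-c2ccccc2Cl)s1` has not yet been measured. It differs from compound 3 by phenyl in place of methyl on an amine nitrogen. Going by the values given here, the one measured step that touches the same part of the molecule is a 1.2-fold lower number from compound 1 to compound 3 (0.07 log units; within the scatter), where a swap of the groups on the two nitrogens stayed within the scatter. The other step, a 4.3-fold higher number from compound 2 to compound 3 (0.63 log units; beyond the scatter), concerns the group on the aromatic ring and does not bear on this change. Among the compounds with values here, no measured compound carries a phenyl group at this nitrogen, so a group of this size is untested. The expectation is therefore a step within the scatter in this assay, written as a 1.1-fold lower number from compound 3 to compound 4 (0.03 log units; within the scatter), with wide uncertainty. Compound 4 is estimated at 40 mg/kg, ranging from 15 mg/kg to 120 mg/kg.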

Compound 4, dose for half-maximal effect: > 100 mg/kg
Compound 4: no number, only a limit (the forecaster's own chance of this, stated with the estimate: 10%); middle value at least 2.5-fold (0.39 log units) away from the limit.
By their numbers in this assay, from the lowest: compound 2; then compounds 3 and 1 (each within the scatter of the next). At a limit, above all of these: compound 4.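

In this assay compound 4 gives > 100 mg/kg, which is a limit of the assay and not a number, and it is the only compound shown that ends at such a limit: the limit of > 100 mg/kg in this assay, at which 1 of the 4 values shown sits. Putting phenyl in place of methyl on an amine nitrogen gives an at least 2.3-fold higher number from compound 3 to compound 4 (0.36 log units; beyond the scatter), a step beyond the scatter, whereas the earlier change of groups on the two nitrogens, a 1.2-fold lower number from compound 1 to compound 3 (0.07 log units; within the scatter), stayed within it. This nitrogen is therefore not indifferent to what it carries: the methylamino to anilino change is the first shown at this part of the molecule to move the read-out beyond the scatter, a shift toward needing larger amounts of compound.

The limit leaves open how far compound 4 really lies from compound 3, and a single change cannot separate the effect of an aromatic ring from that of a larger group, a question that ethyl, cyclohexyl or benzyl on the same nitrogen could address. As far as these compounds go, it is also open whether phenyl here would have the same outcome alongside methyl instead of chloro on the aromatic ring, the change seen in a 4.3-fold higher number from compound 2 to compound 3 (0.63 log units; beyond the scatter).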